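A few compounds are considered here, and "the series" means these few. Any claim that something is new, unique, unknown or untested is made for them only; others in the source may bear on it.

Working notes on the series. Compound 1 `Oc1cc(C(F)(F)F)ccc1-c1nc(-c2ccccc2O)n(-c2ccc(F)cc2)n1` in a functional assay on PC-12 cells (Rattus norvegicus) for cytotoxicity, read by MTT assay, with stated times of 2 h and 24 h, tested at 5 uM (a higher number here means a stronger effect of the compound at the concentration tested, a lower number a weaker effect), gives 86.7%. Compound 2 `N#Cc1ccc(-n2nc(-c3ccc(C(F)(F)F)cc3O)nc2-c2ccccc2O)cc1` in this assay gives 86.8%; the step of a number 0.1 percentage points higher from compound 1 to compound 2 (within the scatter) shows that swapping fluoro for cyano on the phenyl that sits on the aromatic nitrogen of the five-membered ring left the read-out where it was. On the two numbers to hand, compound 2 and compound 1 lie within the scatter of each other, so neither can be ranked above the other.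

Compound 3 `Oc1cc(C(F)(F)F)ccc1-c1nc(-c2ccccc2O)n(-c2cccc(C(F)(F)F)c2)n1` is not yet measured. Its difference from compound 2 is 3-(trifluoromethyl)phenyl in place of 4-cyanophenyl on an aromatic nitrogen. Going by the values given here, the only measured step that bears on this change is the one from compound 1 to compound 2, which also exchanged the group on that aromatic nitrogen and amounted to a number 0.1 percentage points higher from compound 1 to compound 2 (within the scatter), a shift within the scatter. With a single comparison of this kind, and that one flat, no step beyond the scatter is expected in this assay in either direction; the expected step of a number 2.8 percentage points lower from compound 2 to compound 3 (within the scatter) is small. Compound 3 is therefore estimated at 84%, with a range from 68% to 95%.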

Compound 3, a percentage reported as activity, at one concentration (the size of the read-out at that concentration, not a potency): 92.2%
Compound 3: middle estimate off by 8.2 percentage points, on the low side; low and high end bracket the measured number.
By their numbers in this assay, from the lowest: compounds 1, 2 and 3 (each within the scatter of the next).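

Exchanging 4-cyanophenyl for 3-(trifluoromethyl)phenyl on the aromatic nitrogen gives in this assay a step of a number 5.4 percentage points higher from compound 2 to compound 3 (within the scatter) and the exchange from 4-fluorophenyl gives a number 5.5 percentage points higher from compound 1 to compound 3 (within the scatter) so all three groups at this place remain within the scatter of one another. Unlike the earlier exchange of fluoro for cyano, this change replaces a group named as 4-substituted with one named as 3-substituted and also swaps the substituent itself, and even this double change does not separate the compounds in this read-out at the single concentration tested. Nothing on hand accounts for the read-out at this position.

The compounds shown cannot separate the effect of where the substituent sits from that of which substituent it is, so 4-(trifluoromethyl)phenyl and 3-cyanophenyl on the same nitrogen remain open comparisons. Also open, going by these compounds, is whether a different kind of group at this place, such as an aminophenyl, a carboxylic acid on the phenyl or a plain alkyl chain in place of the phenyl, would stand apart from these three.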